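This account rests on a few compounds, and the source may have more. Where it says the series, first, only, none or still open, it means among the compounds named here.

Of the compounds shown here, three have so far been tested in a functional assay on CCRF-CEM cells (Homo sapiens) for antiproliferative activity; on this read-out lower numbers stand for stronger inhibition and higher numbers for weaker inhibition. Compound 1 `Nc1nc(=O)n([C@H]2C=C[C@@H](CO)O2)cc1Br` gives 42500 nM. Compound 2 `Nc1nc(=O)n([C@H]2C=C[C@@H](CO)O2)cc1I` gives 107000 nM. For the measured compounds named here, that comparison, with iodo in place of bromo on an aromatic carbon, is the only measured step in the set: a 2.5-fold higher number from compound 1 to compound 2 (0.40 log units; beyond the scatter), a modest change beyond the scatter.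

Compound 3 `CC(=O)OC[C@@H]1C=C[C@H](n2cc(F)c(N)nc2=O)O1` has no exact number, and its > 100000 nM is a limit of the assay. Compound 4 `CCCCC(=O)OC[C@@H]1C=C[C@H](n2cc(F)c(N)nc2=O)O1` differs from compound 3 at one place: propyl in place of hydrogen on a saturated chain carbon bound to a carbonyl carbon. Cut one bond further out, the same difference reads acetoxy to (butylcarbonyl)oxy.

Going by the values given here, no measured step involves this chain, and the step of a 2.5-fold higher number from compound 1 to compound 2 (0.40 log units; beyond the scatter) bears on the question only indirectly, as a guide to how large a single change has been. With only a limit as the starting point, the data fix neither size nor direction. A modest change at most is expected, leaning towards a lower number, and compound 4 may well remain at the limit.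

The expected change is an at least 1.1-fold lower number from compound 3 to compound 4 (0.04 log units; that floor lies within the scatter). In this assay, the estimated value for compound 4 is 90000 nM, with an expected range of 30000 nM to 200000 nM.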

Compound 4, half-maximal inhibitory concentration: 124000 nM
Beside the measured number, compound 4's estimate is 1.4-fold (0.14 log units) below it, within the range that was stated.
By their numbers in this assay, from the lowest: compound 1; then compounds 2 and 4 (each within the scatter of the next).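

No size or direction can be read for the change from compound 3 to compound 4 in this assay, because compound 3 carries a limit and not a number: the limit of > 100000 nM in this assay, at which 1 of the 4 values shown sits. The compounds shown leave open how the butylcarbonyl group of compound 4 compares with the acetyl group of compound 3 on this read-out.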